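Quinolinone imines and hydrazones: one desmethyl step

The source may report more compounds than this note shows. Statements on the series, on what has been measured and on what is new or still open speak of the compounds shown alone.

Measured compounds:
Compound 1, `Cc1ccc2[nH]c(=O)c(/C=N/Nc3ccc([N+](=O)[O-])cc3[N+](=O)[O-])cc2c1`, 144000 nM.
Compound 2, `Cc1ccc2[nH]c(=O)c(/C=N/c3ccc(S(N)(=O)=O)cc3)cc2c1`, 1200000 nM.
Compound 3, `O=c1[nH]c2ccccc2cc1/C=N/Nc1ccc([N+](=O)[O-])cc1[N+](=O)[O-]`, 142000 nM.

All three were run in a functional assay, read by spectrophotometry, with a stated time of 3 min; on this read-out lower numbers stand for stronger inhibition and higher numbers for weaker inhibition. Compound 1 and compound 3 differ in one place, (hydrogen in place of methyl on an aromatic carbon), and the step is a 1.0-fold lower number from compound 1 to compound 3 (0.01 log units; within the scatter). Compound 2 stands apart from both: the difference between its core and the core of compound 1 is not broken down here, and its number is the highest of the three, beyond the scatter from either of the others.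

Compound 4, `NS(=O)(=O)c1ccc(/N=C/c2cc3ccccc3[nH]c2=O)cc1`, is not yet measured. Among the compounds with values here, it is reached from compound 2 by hydrogen in place of methyl on an aromatic carbon, which is the same change as the one from compound 1 to compound 3; the place is described in the same words in both cases. Since that earlier step stayed within the scatter, a step of about the same size is expected from compound 2 to compound 4, no change at the digits printed from compound 2 to compound 4 (within the scatter). The expected value for compound 4 in this assay is 1200000 nM, with a range from 500000 nM to 2800000 nM.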

Compound 4, half-maximal inhibitory concentration: 1610000 nM
Estimate against measurement, compound 4: 1.3-fold (0.13 log units) below; the measured number falls inside the stated range.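

In this assay, replacing the methyl on the aromatic carbon with hydrogen gives a 1.3-fold higher number from compound 2 to compound 4 (0.13 log units; within the scatter), so on this second core the change again stays inside the usual spread of repeated measurements. The two steps do not differ, and the change carries over between the two cores examined: the same change on two cores in this assay, a 1.0-fold lower number (0.01 log units; within the scatter) from compound 1 to compound 3 and a 1.3-fold higher number (0.13 log units; within the scatter) from compound 2 to compound 4, 1.4-fold (0.13 log units) apart, within the scatter of two such steps. This supports treating hydrogen and methyl at this place as interchangeable for these two pairs only; it does not show that the same would hold on a further core, nor does it explain why the methyl makes no measurable difference.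

As far as these compounds go, only methyl and hydrogen appear at this place, so the effect of a longer chain, a methoxy group, a chlorine atom, an amine or a carboxylic acid on the same aromatic carbon remains open. From the compounds shown here alone, the other part of the molecule, where compound 2 differs from compound 1 in more than one place, also remains open, as no single change there can be read from these compounds.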